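The compounds below may be only part of what the source reports. "The series", "measured", "known", "first", "only" and "open" are said of these compounds alone.

Series notes. In an assay on isolated protein with Bile acid receptor (Homo sapiens) as the target (on this read-out lower numbers stand for an effect already at smaller amounts and higher numbers for an effect only at larger amounts of compound), compound 1 `COC(=O)/C=C/c1cccc(N(Cc2ccc(-c3ccc(F)c(F)c3)cc2)C(=O)C2CCCCC2)c1` gives 72 nM, the lowest of the two numbers shown. In this assay compound 2 `COC(=O)/C=C/c1cccc(N(Cc2ccc(-c3cccc(OC(F)(F)F)c3)cc2)C(=O)C(C)C)c1` gives 247 nM, a gap from compound 1 beyond the usual scatter. Compound 3 `CC(C)(C)OC(=O)/C=C/c1ccc(CN(C(=O)C2CCCCC2)c2cccc(/C=C/C(N)=O)c2)cc1` sits in this assay at > 1000 nM, which is a limit of the assay and not a number (the limit of > 1000 nM in this assay, at which 1 of the 3 values shown sits). Compound 4 `COC(=O)/C=C/c1cccc(N(Cc2ccc(Br)cc2)C(=O)C2CCCCC2)c1` is not yet measured. It differs from compound 1 by bromo in place of 3,4-difluorophenyl on an aromatic carbon; the change drops one six-membered aromatic ring of carbon only and puts a single heavy atom in its place. Within the data shown here, no measured step covers such a change, so a loss beyond the scatter in this assay is expected. The expected step is a 6.9-fold higher number from compound 1 to compound 4 (0.84 log units; beyond the scatter). Compound 4 is estimated at 500 nM, within 150 nM to 2000 nM.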

Compound 4, half-maximal effective concentration: > 1000 nM
Compound 4: a limit, no number (the forecaster's own chance of this, stated with the estimate: 25%); middle value at least 2.0-fold (0.30 log units) from the limit.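

Among these compounds, compound 4 gives the first step that differs in one place: in this assay, the change of 3,4-difluorophenyl to bromo gives an at least 13-fold higher number from compound 1 to compound 4 (1.14 log units; beyond the scatter). At this position, para to a large group, a single bromo therefore does not stand in for the aromatic ring of compound 1. The value of compound 4 is a limit and not a number, so the full size of the step stays unknown: the limit of > 1000 nM in this assay, at which 2 of the 4 values shown sit.

The compounds shown leave open whether the two fluorines contribute or the ring alone suffices. An unsubstituted phenyl at this position would separate these two readings, and a methoxy or an amine would test other small groups in place of bromo.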